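Shortening the thioether chain to an ethyl ester

The source may report more compounds than this note shows. Statements on the series, on what has been measured and on what is new or still open speak of the compounds shown alone.

Three compounds share one core and differ only in the chain on the sulfur. Compound 1 `O=C(O)Cn1c(SCCCc2ccccc2)nc2ccccc21` gives 475 nM in an assay on HEK293 cells for displacement of a labelled ligand from prostaglandin D2 receptor 2 (Homo sapiens); a higher number here means a weaker inhibitor, a lower number a stronger inhibitor; compound 2 `O=C(O)Cn1c(SCCCNc2ccccc2)nc2ccccc21` gives 2690 nM; compound 3 `CCCCCCSc1nc2ccccc2n1CC(=O)O` gives 1360 nM, the second highest of the three numbers. The steps of a 2.9-fold higher number from compound 1 to compound 3 (0.46 log units; beyond the scatter) and a 5.7-fold higher number from compound 1 to compound 2 (0.75 log units; beyond the scatter) show that swapping the chain end moves the number modestly, while a 2.0-fold lower number from compound 2 to compound 3 (0.30 log units; within the scatter) stays within the scatter. Compound 4 `CCOC(=O)CCSc1nc2ccccc2n1CC(=O)O` carries ethoxycarbonyl in place of butyl on a saturated chain carbon, two bonds along the chain from a sulfur. Among the compounds with values here, no measured step exchanges an alkyl end for an ester, so the closest guide is the modest size of the earlier steps. Compound 4 is expected at 2500 nM, between 800 nM and 8000 nM, with the step of a 1.8-fold higher number from compound 3 to compound 4 (0.26 log units; within the scatter) estimated as a small weakening.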

Compound 4, half-maximal inhibitory concentration: 11400 nM
For compound 4 the middle estimate is 4.6-fold (0.66 log units) below the measured one, outside the stated range (above it).
By their numbers in this assay, from the lowest: compound 1; then compounds 3 and 2 (each within the scatter of the next); then compound 4.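

An ethoxycarbonyl end gives a bigger step than any earlier change of chain end (an 8.4-fold higher number from compound 3 to compound 4 (0.92 log units; beyond the scatter)), and it opens the first large gap in this set (a 24-fold higher number from compound 1 to compound 4 (1.38 log units; beyond the scatter)). Even the anilino chain of compound 2 gives a clearly lower number (a 4.2-fold higher number from compound 2 to compound 4 (0.63 log units; beyond the scatter)), so this position tolerates a new chain end less well than the first three compounds suggested. No measurement here explains the loss. Still open, going by these compounds, is how a carboxylic acid or an amide at the chain end would compare, and whether the ester behaves the same on a longer chain.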